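The compounds below may be only part of what the source reports. "The series", "measured", "known", "first", "only" and "open" are said of these compounds alone.

Three compounds share one core and differ only in the group carried on one amide-type nitrogen of a urea. Compound 1 `O=C(Nc1ccccc1Cl)Nc1nn(-c2ccccc2)c(=O)c2ccccc12` gives 0% in an assay on CHO cells for displacement of a labelled ligand from adenosine receptor A1 (Homo sapiens), tested at 10 uM (a higher number here means more inhibition at the concentration tested (going by the name of the read-out), a lower number less inhibition), the lowest of the three numbers. Compound 2 `O=C(NCc1ccccc1)Nc1nn(-c2ccccc2)c(=O)c2ccccc12` gives 20% in this assay, and compound 3 `Cc1ccccc1NC(=O)Nc1nn(-c2ccccc2)c(=O)c2ccccc12` gives 20% in this assay. The two changes away from compound 1 are both modest: a number 20 percentage points higher from compound 1 to compound 2 (beyond the scatter) and a number 20 percentage points higher from compound 1 to compound 3 (beyond the scatter). Between the two better compounds, no change at the digits printed from compound 2 to compound 3 (within the scatter), so compound 3 stands level with compound 2, and together they are the highest pair of the three, with compound 1 at the far end.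

Compound 4 `COc1ccccc1CNC(=O)Nc1nn(-c2ccccc2)c(=O)c2ccccc12` is the next step. The change from compound 3 is 2-methoxybenzyl in place of 2-methylphenyl on an amide-type nitrogen.

Among the compounds with values here, two measured steps bear on this. The swap of a phenyl group for a benzyl group, from compound 2 to compound 3, was within the scatter, so inserting the extra carbon between the nitrogen and the ring by itself is not expected to move the number. The swap of chloro for methyl, from compound 1 to compound 3, was worth only a modest change. Within the data shown here, no measured step covers a methoxy group, so the effect of that part is unknown. The expectation is therefore a step of no change at the digits printed from compound 3 to compound 4 (within the scatter), no larger than the scatter, in no clear direction.

Compound 4 is estimated at 20% in this assay, within a range of 5% to 35%.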

Compound 4, a percentage reported as inhibition, at one concentration (the size of the read-out at that concentration, not a potency): 28%
For compound 4 the middle estimate is 8 percentage points below the measured one, and the stated range covers the measured number.
By their numbers in this assay, from the lowest: compound 1; then compounds 2, 3 and 4 (each within the scatter of the next).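

In this assay, replacing the 2-methylphenyl group on this amide-type nitrogen with 2-methoxybenzyl gives a step that cannot be told from the scatter (a number 8 percentage points higher from compound 3 to compound 4 (within the scatter)). Adding a methoxy group to the ring of the benzyl group, the first measured step to involve this group, also stays within the scatter (a number 8 percentage points higher from compound 2 to compound 4 (within the scatter)), so the number is level across both of these changes, while the step from the 2-chlorophenyl group remains clear (a number 28 percentage points higher from compound 1 to compound 4 (beyond the scatter)). Compound 1 is thus the only one set apart from the others, and no measurement here offers an explanation for that difference.

From the compounds shown here alone, whether the low number of compound 1 goes with the chloro group itself or with the ring sitting directly on the nitrogen remains open, and a 2-chlorobenzyl group would separate those two possibilities. Also open, going by these compounds, is whether a longer chain such as 2-phenylethyl, or an amine or carboxylic acid on the ring, would move the number beyond the scatter of compounds 2, 3 and 4.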